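Cyano for bromo on the aryl ring of compound 2

The source may report more compounds than this note shows. Statements on the series, on what has been measured and on what is new or still open speak of the compounds shown alone.

Measured compounds:
compound 1, `Cn1nnnc1SCC(=O)N/N=c1/scc(-c2ccc(C#N)cc2)n1-c1ccccc1`, 63.5% in a functional assay on C6 cells (Rattus norvegicus) for cytotoxicity, read by MTT assay, with a stated time of 24 h, tested at 6 ug/mL; a higher number here means a weaker effect of the compound at the concentration tested, a lower number a stronger effect
compound 2, `O=C(CSc1nnnn1-c1ccccc1)N/N=c1/scc(-c2ccc(Br)cc2)n1-c1ccccc1`, 61.8%

In this assay compound 2 gives 61.8%, and compound 1 gives 63.5%; the gap between the two lies within the scatter, so neither can be set above the other. Compound 3, `N#Cc1ccc(-c2cs/c(=N/NC(=O)CSc3nnnn3-c3ccccc3)n2-c2ccccc2)cc1`, is not yet measured. It differs from compound 2 as follows: cyano in place of bromo on an aromatic carbon. Among the measured compounds shown here, no step between measured compounds covers this change, and the values of compound 1 and compound 2 give no sign that the aryl substituent moves the read-out. For compound 3 the expected step is a number 0.2 percentage points higher from compound 2 to compound 3 (within the scatter), that is, none beyond the scatter. Compound 3 is thus estimated at 62%, within 50% to 75%.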

Compound 3, a percentage reported as activity, at one concentration (the size of the read-out at that concentration, not a potency): 78.8%
Beside the measured number, compound 3's estimate is 16.8 percentage points below it; the whole stated range lies below it.
By their numbers in this assay, from the lowest: compounds 2 and 1 (each within the scatter of the next); then compound 3.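

In this assay, the aryl substituent does move the read-out once the rest of the molecule is held fixed: with cyano in place of bromo, a number 17 percentage points higher from compound 2 to compound 3 (beyond the scatter), a weaker effect at the concentration tested. The group on the aromatic nitrogen matters as well: with phenyl in place of methyl, a number 15.3 percentage points higher from compound 1 to compound 3 (beyond the scatter), again a weaker effect. Nothing here gives a cause for either step.

Still open, from the compounds shown here alone, is whether an amine or a carboxylic acid on that aromatic carbon would shift the read-out. Going by these compounds, a longer chain on the aromatic nitrogen is equally open.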